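Half-life notes: difluoromethyl to 2-methoxyethyl

The source may report more compounds than this note shows. Statements on the series, on what has been measured and on what is new or still open speak of the compounds shown alone.

In an ADME assay (liver, Mus musculus) for metabolic stability, using microsomes (on this read-out higher numbers stand for a longer-lived compound and lower numbers for a shorter-lived compound), compound 1 (`C=CC(=O)Nc1cccc(CNc2nc(Nc3cc(F)c(N4CCN(C(C)=O)CC4)c(F)c3)ncc2Cl)c1`) gives 0.0567 h, compound 2 (`C=CC(=O)Nc1cccc(CNc2nc(Nc3cn(C)nc3C)ncc2Cl)c1`) gives 0.138 h and compound 3 (`C=CC(=O)Nc1cccc(CNc2nc(Nc3cnn(C(F)F)c3)ncc2Cl)c1`) gives 0.173 h. Compound 3 stands clear of compound 1, a gap beyond the scatter, and is level with compound 2 within the scatter.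

Compound 4 (`C=CC(=O)Nc1cccc(CNc2nc(Nc3cnn(CCOC)c3)ncc2Cl)c1`) carries 2-methoxyethyl in place of difluoromethyl on an aromatic nitrogen. Among the compounds with values here, the one measured step bearing on this change is a 1.3-fold higher number from compound 2 to compound 3 (0.10 log units; within the scatter). It also exchanges groups on the 1H-pyrazol-4-yl ring and stays within the scatter. Within the data shown here, no measured compound carries 2-methoxyethyl, so the evidence for this group is indirect and the range is kept wide.

On that basis, no step beyond the scatter is expected in this assay, and the estimated step is a 1.2-fold lower number from compound 3 to compound 4 (0.09 log units; within the scatter). For compound 4 the estimated value is 0.14 h, with an expected range of 0.07 h to 0.28 h.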

Compound 4, half-life: 0.055 h
Compound 4: middle estimate off by 2.5-fold (0.41 log units), on the high side; measured number outside the range, below it.
By their numbers in this assay, from the lowest: compounds 4 and 1 (each within the scatter of the next); then compounds 2 and 3 (each within the scatter of the next).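

In this assay, the aromatic nitrogen of the five-membered ring proves sensitive to what it carries: 2-methoxyethyl in place of difluoromethyl gives a 3.1-fold lower number from compound 3 to compound 4 (0.50 log units; beyond the scatter), whereas the earlier exchange of ring groups gave only a 1.3-fold higher number from compound 2 to compound 3 (0.10 log units; within the scatter). The 1-(2-methoxyethyl)-1H-pyrazol-4-yl group also separates from 1,3-dimethyl-1H-pyrazol-4-yl, with a 2.5-fold lower number from compound 2 to compound 4 (0.40 log units; beyond the scatter), so the two earlier groups read level with each other and the new chain falls away from both. Nothing at hand accounts for this drop.

From the compounds shown here alone, whether a plain alkyl chain such as propyl, or a 2-hydroxyethyl group, on this aromatic nitrogen would read like 2-methoxyethyl or like difluoromethyl stays open. So does whether a chain ending in an amine would follow the same direction.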